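Compound 3: ethyl in place of 4-chlorophenyl

The source may report more compounds than this note shows. Statements on the series, on what has been measured and on what is new or still open speak of the compounds shown alone.

In an ADME assay on BHK cells (Mesocricetus auratus) for cytotoxicity, read by MTT assay, with a stated time of 96 h (a higher number here means that more compound is tolerated, a lower number that less compound is tolerated), compound 1 `FC(F)(F)c1cccc(NC(=S)Nc2ccc(Cl)cc2)c1` gives 10000 nM. Compound 2 `CCCC[C@H]1CC[C@H](c2ccc(NC(=S)Nc3cccc(C(F)(F)F)c3)cc2)CC1` gives 9500 nM. Within the data shown here, these two values lie within the scatter of each other, so compound 1 has no rank of its own on the numbers so far.

Compound 3 `CCNC(=S)Nc1cccc(C(F)(F)F)c1` is the next case, still unmeasured, and its change from compound 1 is ethyl in place of 4-chlorophenyl on an amide-type nitrogen. The rest of the core of compound 1 is kept.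

Among the measured compounds shown here, only one measured step bears on this: a 1.1-fold lower number from compound 1 to compound 2 (0.02 log units; within the scatter), with 4-butylcyclohexyl in place of chloro on an aromatic carbon. That step lies within the scatter, but it is at another place and only weakly informs the new change. For the measured compounds named here, no step at the amide-type nitrogen has been measured, so the direction is poorly defined.

The expected change is a 1.5-fold higher number from compound 1 to compound 3 (0.18 log units; within the scatter), which is no shift beyond the scatter. Compound 3 is estimated at 15000 nM, with an expected range from 5000 nM to 60000 nM.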

Compound 3, half-maximal cytotoxic concentration: > 100000 nM
Compound 3 gave a limit, no number; the forecaster's own chance of this, stated with the estimate: 30%; middle value at least 6.6-fold (0.82 log units) from the limit.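

In this assay, among these compounds, the amide-type nitrogen is the first place where a change moves the number beyond the scatter: ethyl in place of 4-chlorophenyl gives an at least 10-fold higher number from compound 1 to compound 3 (1.00 log units; beyond the scatter), whereas exchanging only the chloro on that aromatic ring gives a 1.1-fold lower number from compound 1 to compound 2 (0.02 log units; within the scatter). Compound 3 gives a limit and not a number, > 100000 nM. On these data alone, the size of the step therefore stays open on the upper side, with one compound at that limit: the limit of > 100000 nM in this assay, at which 1 of the 3 values shown sits.

The compounds shown leave open whether the step follows the loss of the aromatic ring or the drop in heavy atoms, as ethyl is the only replacement for 4-chlorophenyl at this nitrogen. A longer chain or a phenyl without chloro on the amide-type nitrogen would bear on that question, and a carbonyl in place of the thiocarbonyl would test a different part of the core of compound 1.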